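From a Fluoroethyl Oxime Ether to an Oxime Ester

This account rests on a few compounds, and the source may have more. Where it says the series, first, only, none or still open, it means among the compounds named here.

Measured so far in a functional assay (blood) for inhibition, with Homo sapiens as the target; a higher number here means a weaker inhibitor, a lower number a stronger inhibitor:
- compound 1 `OC1O[C@H](CO/N=C2\CCc3cc(Sc4cc(F)cc(C5CCOCC5)c4)ccc32)[C@H](O)[C@H](O)[C@H]1O`: > 2500 nM
- compound 2 `C/C(=N\OCCF)c1ccc(Sc2cc(F)cc(C3CCOCC3)c2)cc1`: 40 nM
- compound 3 `C/C(=N\O)c1ccccc1Sc1cc(F)cc(C2CCOCC2)c1`: > 10000 nM

Compound 2 is the only one of the three with a real number in this assay. For compound 1 the result is a limit of the assay, (the limit of > 2500 nM in this assay, at which 1 of the 3 values shown sits). For compound 3 the result is likewise a limit, (the limit of > 10000 nM in this assay, at which 1 of the 3 values shown sits). Among the measured compounds shown here, nothing else links these three, so they show only that compound 2 is the one measurable inhibitor here.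

Compound 4 `C/C(=N\OC(=O)C(C)(C)C)c1ccc(Sc2cc(F)cc(C3CCOCC3)c2)cc1` is not yet measured. It differs from compound 2 in one place: (tert-butyl)carbonyl in place of 2-fluoroethyl on an oxygen. For the measured compounds named here, no measured pair shows a change like this, so the expected step from compound 2 to compound 4 in this assay is a 2.0-fold higher number from compound 2 to compound 4 (0.30 log units; within the scatter), a modest weakening that may still lie within scatter. Compound 4 is therefore expected to give about 80 nM, between 20 nM and 400 nM.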

Compound 4, half-maximal inhibitory concentration: 40 nM
For compound 4 the middle estimate is 2.0-fold (0.30 log units) above the measured one; the range from low to high includes it.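

In this assay there is no change at the digits printed from compound 2 to compound 4 (within the scatter), so this oxygen, bonded to the double-bonded nitrogen, now has two groups with real numbers rather than one. The (tert-butyl)carbonyl group has more heavy atoms than 2-fluoroethyl and adds a carbonyl, yet the inhibition read-out stays level. Nothing measured here explains why these two groups read alike.

Two groups cannot define what this position accepts. On these data alone, whether a chain ending in an amine or a carboxylic acid would read the same at this oxygen remains open.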